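A few compounds are considered here, and "the series" means these few. Any claim that something is new, unique, unknown or untested is made for them only; others in the source may bear on it.

The measured compounds:
compound 1 `O=C(O)CCCCCCN1C(=O)CCC1CCC(O)CCc1ccccc1` gives > 3200 nM in an assay on HEK293 cells for binding affinity to prostaglandin E2 receptor EP4 subtype (Rattus norvegicus); a lower number here means a stronger inhibitor, a higher number a weaker inhibitor.
compound 2 `O=C(O)CCCCCCN1C(=O)CC[C@@H]1CC[C@@H](O)CCc1ccccc1` gives 2710 nM in this assay.

Compound 1 stands only at a limit of the assay: in this assay compound 1 gives > 3200 nM, which is a limit and not a number. Going by the values given here, the one measured step, an at least 1.1-fold lower number from compound 1 to compound 2 (0.07 log units; that floor lies within the scatter), is known only as a floor because of the limit of > 3200 nM in this assay, at which 1 of the 2 values shown sits, and the two compounds differ only in how their stereocentres are drawn, as the fact that one of compounds 1 and 2 is drawn with a defined configuration and the other without, at the place where they differ shows.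

Compound 3 `O=C(O)CCCCCCN1C(=O)CCC1CCC(O)Cc1cccc(Cl)c1` differs from compound 1 by 3-chlorophenyl in place of benzyl on a saturated chain carbon, two bonds along the chain from an oxygen on a saturated carbon. No measured step touches the aromatic end of the chain, so this change has no precedent among the numbers shown. With compound 1 itself at a limit, compound 3 is expected to stay in the same weak region, with a step that the limit leaves unreadable from compound 1 to compound 3 not beyond the scatter. The estimate for compound 3 is 4000 nM, with a range from 1200 nM to 15000 nM.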

Compound 3, half-maximal inhibitory concentration: 22 nM
The estimate for compound 3 lay 180-fold (2.26 log units) above the measured number; the whole stated range lies above it.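

In this assay, the aromatic end of the chain proves to be a place where a single change moves the number far: 3-chlorophenyl in place of benzyl, on a saturated chain carbon, two bonds along the chain from an oxygen on a saturated carbon, gives an at least 140-fold lower number from compound 1 to compound 3 (2.16 log units; beyond the scatter). The earlier compounds shown here showed no step beyond the scatter. Compound 1 gives > 3200 nM, which is a limit and not a number, and the true size of the step stays unknown because it is only a floor set by that limit: the limit of > 3200 nM in this assay, at which 1 of the 3 values shown sits.

The same difference reads as phenethyl to 3-chlorobenzyl, so the compounds shown do not separate the shorter chain from the added chlorine. Also open, from the compounds shown here alone, is how a fluorine or a methoxy group in place of that chlorine would read in this assay, and what a defined configuration would do on compound 3.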